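Acetyl for heptyl: a change in the aryl urea series

The source may hold more compounds than are shown below. What is called first, only, known or untested is meant among the compounds shown, and "the series" means these compounds.

Measured compounds:
compound 1, `Cc1ccc(NC(=O)N[C@@H](C)c2ccccc2)cc1`, 99%
compound 2, `CCCCCCCc1ccc(NC(=O)N[C@@H](C)c2ccccc2)cc1`, 99%

In an ADME assay on the whole organism with Oryza sativa as the target, tested at 1 uM (a higher number here means a weaker effect of the compound at the concentration tested, a lower number a stronger effect), compound 1 gives 99%, and compound 2 gives 99%. For the measured compounds named here, the only step between measured compounds, no change at the digits printed from compound 1 to compound 2 (within the scatter), shows that lengthening the chain on the core of compound 1 leaves the read-out where it was. Compound 2 therefore stands level with compound 1 at the digits shown, within the scatter.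

Compound 3, `CC(=O)c1ccc(NC(=O)N[C@@H](C)c2ccccc2)cc1`, has not yet been measured. It differs from compound 2 in one place: acetyl in place of heptyl on an aromatic carbon. Going by the values given here, no measured step replaces an alkyl chain by a carbonyl-bearing group, so the one step on record, no change at the digits printed from compound 1 to compound 2 (within the scatter), bears on it only loosely: it shows that a change of size at this aromatic carbon did not move the read-out. On that basis the step from compound 2 to compound 3 is expected to be small, a number 2 percentage points lower from compound 2 to compound 3 (within the scatter), with no direction beyond the scatter. Compound 3 is estimated to give 97%, between 85% and 100%.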

Compound 3, a percentage reported as activity, at one concentration (the size of the read-out at that concentration, not a potency): 99%
Beside the measured number, compound 3's estimate is 2 percentage points below it; measured number inside the range.
By their numbers in this assay, from the lowest: compounds 1, 2 and 3 (each within the scatter of the next).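

In this assay, for the compounds shown here, this result covers a kind of change the earlier compounds did not: only alkyl groups had stood on this aromatic carbon, para to a large group, and acetyl brings a carbonyl and a hydrogen-bond acceptor where heptyl has none, yet the exchange gives no change at the digits printed from compound 2 to compound 3 (within the scatter). The comparison with the short chain agrees, with no change at the digits printed from compound 1 to compound 3 (within the scatter), so methyl, heptyl and acetyl cannot be told apart at this position in this read-out, and neither the size of the group nor the presence of the acceptor separates the three compounds. Nothing on hand explains why these groups read alike.

On these data alone, since all three compounds stand level, it remains open whether any group at this position can shift the read-out at all, and an amine or a carboxylic acid on this aromatic carbon would put that to a sharper test. As far as these compounds go, it also remains open whether a change elsewhere on the shared core, such as at the urea or on the other aromatic ring, would separate compounds that this position does not.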